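Neopentylcarbonyl ester of an adenosine nucleoside

A few compounds are considered here, and "the series" means these few. Any claim that something is new, unique, unknown or untested is made for them only; others in the source may bear on it.

Going by the values given here, compound 2 `CC(=O)OC[C@H]1O[C@@H](n2cnc3c(N)ncnc32)[C@@H](O)[C@@H]1O` holds the only plain number in a physicochemical assay for lipophilicity, using the shake flask method, in phosphate buffer, with a stated time of 1 h; on this read-out lower numbers stand for lower lipophilicity and higher numbers for higher lipophilicity: compound 2 gives 0.12. Compound 1 `CCCCCCCC(=O)OC[C@H]1O[C@@H](n2cnc3c(N)ncnc32)[C@@H](O)[C@@H]1O` gives >= 2, which is a limit of this assay and not a number; the evidence is the limit of >= 2 in this assay, at which 1 of the 2 values shown sits. Among the compounds with values here, the single measured step is a number at least 1.88 log units lower from compound 1 to compound 2 (beyond the scatter), a large move. Compound 3 `CC(C)(C)CC(=O)OC[C@H]1O[C@@H](n2cnc3c(N)ncnc32)[C@@H](O)[C@@H]1O` differs from compound 2 by tert-butyl in place of hydrogen on a saturated chain carbon bound to a carbonyl carbon. Because a number at least 1.88 log units lower from compound 1 to compound 2 (beyond the scatter) was large, an upward step of a number 1.38 log units higher from compound 2 to compound 3 (beyond the scatter) is expected for this smaller addition. Compound 3 is therefore estimated at 1.5, within 1 to 2.1.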

Compound 3, partition coefficient: 1.7
For compound 3 the middle estimate is 0.20 log units below the measured one, within the range that was stated.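

Tert-butyl in place of hydrogen on a saturated chain carbon bound to a carbonyl carbon gives, in this assay, a number 1.58 log units higher from compound 2 to compound 3 (beyond the scatter), so this position now has a large upward move read between two plain numbers. Compound 1 gives >= 2, which is a limit of the assay and not a number. Set against that limit, tert-butyl in place of hexyl gives a number at least 0.30 log units lower from compound 1 to compound 3 (that floor lies within the scatter), so no order of these two chains can be claimed. The compounds shown leave open how hexyl and tert-butyl truly compare, and how an amine or a carboxylic acid on this chain would read in this assay.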